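The compounds below may be only part of what the source reports. "The series", "measured", "known", "first", "only" and "open" are said of these compounds alone.

Working notes on the series.

Compound 1 `C=C1CCCC(C)(C)C1CC[C@]1(C)CC[C@@H]([C@@H](C)C(=O)O)OO1` has been tested in a functional assay on SF-295 cells (Homo sapiens) for inhibition; a higher number here means a weaker inhibitor of growth, a lower number a stronger inhibitor of growth. In this assay compound 1 gives > 10000 nM, which is a limit of the assay and not a number. Compound 1 thus stands at the limit of > 10000 nM in this assay, at which 1 of the 2 values shown sits, and no number places it among the others. For the measured compounds named here, the only other measured compound is compound 2 `C=C1CCCC(C)(C)C1(O)CC/C(C)=C/CC[C@]1(C)CC[C@@H]([C@@H](C)C(=O)OC)OO1`; no step between it and compound 1 is counted here, so the two values can only be set side by side. In this assay compound 2 gives > 17500 nM, again a limit and not a number. That second value sits at the limit of > 17500 nM in this assay, at which 1 of the 2 values shown sits. Going by the values given here, both measured compounds therefore end at a limit, and no size of step is known from the data.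

Compound 3 `C=C1CCCC(C)(C)C1CC[C@@]1(C)CC[C@H]([C@@H](C)C(=O)O)OO1` remains to be measured in this assay. It differs from compound 1 as follows: the two compounds have the same atoms and bonds; at least one stereo element is drawn with a configuration in one of them and without one in the other: 2 of 4 stereo elements differ; a stereocentre at a saturated ring carbon is drawn R in compound 1 and S in compound 3; a stereocentre at a saturated ring carbon is drawn S in compound 1 and R in compound 3. With the two configurations swapped and nothing else altered, the step that the limit leaves unreadable from compound 1 to compound 3 is expected to be none beyond the scatter, in either direction. For compound 3 in this assay the estimate is 15000 nM, with a range from 5000 nM to 50000 nM, and the most likely outcome is another limit rather than a number.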

Compound 3, concentration for 50% growth inhibition: 5440 nM
The estimate for compound 3 lay 2.8-fold (0.44 log units) above the measured number; measured number inside the range.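

In this assay, for the compounds shown here, compound 3 gives 5440 nM, the only actual number among the three compounds, so growth inhibition becomes readable with the two ring stereocentres in this arrangement. Compound 1, with the same atoms and bonds, remains at a limit and not a number: the limit of > 10000 nM in this assay, at which 1 of the 3 values shown sits. Swapping the two configurations and changing nothing else gives an at least 1.8-fold lower number from compound 1 to compound 3 (0.26 log units; that floor lies within the scatter), so the printed floor of the step does not by itself establish a change beyond the scatter.

On these data alone, the true size of the step above that floor stays open while the value for compound 1 is only a limit. Also open, as far as these compounds go, is how this this assay result would respond if a primary amide replaced the carboxylic acid while the configuration of compound 3 was kept.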